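Oxime ether tail: nitrile replaces ester on compound 1

A few compounds are considered here, and "the series" means these few. Any claim that something is new, unique, unknown or untested is made for them only; others in the source may bear on it.

Measured so far in a functional assay (blood) for inhibition, with Homo sapiens as the target; a higher number here means a weaker inhibitor, a lower number a stronger inhibitor:
Compound 1, `COC(=O)C(C)(C)CO/N=C(\C)c1ccc(Sc2cc(F)cc(C3CCOCC3)c2)cc1`: compound 1 gives 420 nM
Compound 2, `COC1(c2cc(F)cc(Sc3ccc4c(c3)CC/C4=N\O)c2)CCOCC1`: compound 2 gives 290 nM
Compound 3, `CO[C@]1(c2cnc(Sc3ccc(/C(C)=N/O)cc3)s2)CCO[C@@H](C)C1`: compound 3 gives 40 nM

Among these three, compound 1 shows the highest number. Its nearest neighbour is compound 2, whose value lies within the usual scatter of compound 1, so the two cannot be told apart. Compound 3 lies furthest away, with a gap to compound 1 well beyond the scatter. No pair of these compounds differs in only one place, so none of the gaps can be tied to a single structural change.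

Compound 4, `C/C(=N\OCC#N)c1ccc(Sc2cc(F)cc(C3CCOCC3)c2)cc1`, has not yet been measured in this assay. It differs from compound 1 in one place: cyano in place of 1-(methoxycarbonyl)-1-methylethyl on a saturated chain carbon bound to an oxygen on an unsaturated carbon. The oxime ether and the shared core of compound 1 remain; only the tail on the oxygen changes. Within the data shown here, nothing among the measured compounds isolates this tail, so the expectation rests on the value of compound 1 alone. The step from compound 1 to compound 4 is expected to be small, a 1.3-fold lower number from compound 1 to compound 4 (0.12 log units; within the scatter), not clearly beyond the scatter in either direction. Compound 4 is therefore estimated at 320 nM, within 100 nM to 1000 nM.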

Compound 4, half-maximal inhibitory concentration: 20 nM
For compound 4 the middle estimate is 16-fold (1.20 log units) above the measured one, outside the stated range (below it).
By their numbers in this assay, from the lowest: compounds 4 and 3 (each within the scatter of the next); then compounds 2 and 1 (each within the scatter of the next).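

The tail on the oxime oxygen proves to be a sensitive place on this scaffold: in this assay, cyano in place of 1-(methoxycarbonyl)-1-methylethyl gives a 21-fold lower number from compound 1 to compound 4 (1.32 log units; beyond the scatter), with the shared core unchanged. Among these compounds, this is the first difference in the set that can be tied to a single place, and it shows that a tail of 2 heavy atoms is accepted here in place of one with 7. No measurement available here explains the size of this step.

Because the ester, the branching and the chain length all leave in one step while the nitrile enters, the compounds shown do not separate their contributions. As far as these compounds go, it remains open how a plain ethyl chain, a carboxylic acid or a primary amide would read at this place.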